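Chain-end ring size in the hydroxamate series

This account rests on a few compounds, and the source may have more. Where it says the series, first, only, none or still open, it means among the compounds named here.

Compound 2 `O=C(O)CCN(O)C(=O)CCCCCCCCC1CC1` carries a cyclopropyl on a saturated chain carbon, eight bonds along the chain from a carbonyl carbon. In an assay on isolated protein for inhibition of lysine-specific demethylase 6A (Homo sapiens), with a stated time of 1 h (a higher number here means a weaker inhibitor, a lower number a stronger inhibitor), compound 2 gives only a limit, > 100000 nM. Compound 1 `CC(C)CCCCCCCCC(=O)N(O)CCC(=O)O` is the isopropyl counterpart. In this assay compound 1 likewise gives a limit, > 100000 nM. The step that the two limits leave unreadable from compound 1 to compound 2 is therefore not readable; the limit of > 100000 nM in this assay, at which 2 of the 2 values shown sit, sums up where the measured values stand. Compound 3 `O=C(O)CCN(O)C(=O)CCCCCCCCC1CCCCC1` differs from compound 2 by cyclohexyl in place of cyclopropyl on a saturated chain carbon, eight bonds along the chain from a carbonyl carbon. Among the measured compounds shown here, no measured step speaks to a ring of this size at that position, and the only step in the set, from isopropyl to cyclopropyl, has no readable size. The expectation for compound 3 in this assay is no change beyond the scatter, so a step of a number no higher from compound 2 to compound 3 (the limit leaves the size open) is expected. Compound 3 is estimated at 100000 nM, in the range 30000 nM to 300000 nM, most probably again reported only as a limit.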

Compound 3, half-maximal inhibitory concentration: > 100000 nM
Compound 3: no number, only a limit (the forecaster's own chance of this, stated with the estimate: 85%); the middle value lies on the limit itself.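

Compound 3 gives > 100000 nM in this assay, which is a limit, and no step among compound 1, compound 2 and compound 3 can be read: the limit of > 100000 nM in this assay, at which 3 of the 3 values shown sit.

The compounds shown leave open how isopropyl, cyclopropyl and cyclohexyl compare in this assay, and whether any chain-end group on the shared core gives a measurable number.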